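This account rests on a few compounds, and the source may have more. Where it says the series, first, only, none or still open, it means among the compounds named here.

Working notes on the series: in a functional assay on NCI-H23 cells (Homo sapiens) for inhibition, read by sulforhodamine B assay, with a stated time of 48 h (on this read-out higher numbers stand for weaker inhibition of growth and lower numbers for stronger inhibition of growth), compound 1 `O=C(Cc1csc2nc(-c3ccc(Br)cc3)cn12)N/N=C/c1ccccc1` gives 61700 nM, the higher of the two numbers so far. Compound 2 `O=C(Cc1csc2nc(-c3ccc(Br)cc3)cn12)N/N=C/c1ccccc1O` gives 14100 nM. Next is compound 3 `O=C(Cc1csc2nc(-c3ccc(Br)cc3)cn12)N/N=C/c1ccc(Cl)cc1Cl`, which differs from compound 1 as follows: 2,4-dichlorophenyl in place of phenyl on a carbon with a double bond to nitrogen. In words, 2,4-dichlorophenyl stands in place of phenyl on a carbon with a double bond to nitrogen. For the measured compounds named here, only one measured step bears on this, and only loosely: hydroxy in place of hydrogen on an aromatic carbon gave a 4.4-fold lower number from compound 1 to compound 2 (0.64 log units; beyond the scatter). Going by the values given here, that step changes the same phenyl ring but adds a different group, and no chlorine-bearing compound has been measured. A modest move to a lower number in this assay is therefore expected, though a result within the scatter of compound 1 remains possible. The expected change is a 2.5-fold lower number from compound 1 to compound 3 (0.39 log units; beyond the scatter). For compound 3 the estimated value is 25000 nM, with an expected range of 8000 nM to 70000 nM.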

Compound 3, concentration for total growth inhibition: 56200 nM
Estimate against measurement, compound 3: 2.2-fold (0.35 log units) below, within the range that was stated.
By their numbers in this assay, from the lowest: compound 2; then compounds 3 and 1 (each within the scatter of the next).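

In this assay, 2,4-dichlorophenyl in place of phenyl on a carbon with a double bond to nitrogen gives a 1.1-fold lower number from compound 1 to compound 3 (0.04 log units; within the scatter), so adding the two chlorine atoms leaves no readable difference between these compounds. The same position is still not indifferent to its substituent: 2,4-dichlorophenyl in place of 2-hydroxyphenyl gives a 4.0-fold higher number from compound 2 to compound 3 (0.60 log units; beyond the scatter), and among the three compounds only compound 2 stands apart. No supporting data bear on why the values fall this way.

The compounds shown leave open whether a methoxy or an amino group in place of the hydroxy group of compound 2 would give a number close to that of compound 2. They also leave open whether a ring carrying a single chlorine would match compound 1 and compound 3.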